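This account rests on a few compounds, and the source may have more. Where it says the series, first, only, none or still open, it means among the compounds named here.

Working notes on the series in a functional assay on MCF-10A cells (Homo sapiens) for antiproliferative activity, with a stated time of 48 h; a lower number here means that less compound is needed, a higher number that more compound is needed for the effect: compound 1 `COc1ccc2nc(C)cc(NCc3ccccc3)c2c1` gives 28600 nM, compound 2 `COc1cccc(CNc2cc(C)nc3ccc(OC)cc23)c1` gives 12500 nM, and compound 3 `COc1ccc2nc(C)cc(NCc3cccc(N(C)C)c3)c2c1` gives 14000 nM. Compound 3 therefore stands level with compound 2 and apart from compound 1. The two comparisons are a 1.1-fold higher number from compound 2 to compound 3 (0.05 log units; within the scatter) and a 2.0-fold lower number from compound 1 to compound 3 (0.31 log units; beyond the scatter).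

The next change leads to compound 4 `COc1ccc2nc(C)cc(NCc3cccc(CO)c3)c2c1`, with hydroxymethyl in place of dimethylamino on an aromatic carbon, meta to a large group: hydroxymethyl in place of dimethylamino on an aromatic carbon.

Going by the values given here, three measured steps bear on this change. Putting a group in place of hydrogen at this position gave modest steps, a 2.3-fold lower number from compound 1 to compound 2 (0.36 log units; beyond the scatter) and the dimethylamino step already noted. Among the compounds with values here, the only exchange of one group for another, methoxy for dimethylamino, stayed within the scatter. Within the data shown here, both substituted compounds keep numbers close together, but no hydroxymethyl compound has been measured, and neither substituted compound offers a hydrogen-bond donor in this group. That leaves some uncertainty in either direction, with the number of compound 1 as a reasonable upper guide.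

No shift beyond the scatter is expected in this assay. The expected step is a 1.1-fold higher number from compound 3 to compound 4 (0.06 log units; within the scatter). For compound 4 the estimate is 16000 nM, with an expected range of 8000 nM to 30000 nM.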

Compound 4, half-maximal effective concentration: 24700 nM
Beside the measured number, compound 4's estimate is 1.5-fold (0.19 log units) below it; low and high end bracket the measured number.
By their numbers in this assay, from the lowest: compounds 2, 3, 4 and 1 (each within the scatter of the next, the first and the last beyond it).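

In this assay, hydroxymethyl in this place stands within the scatter of each other compound in the series (a 1.8-fold higher number from compound 3 to compound 4 (0.25 log units; within the scatter); a 2.0-fold higher number from compound 2 to compound 4 (0.30 log units; within the scatter); a 1.2-fold lower number from compound 1 to compound 4 (0.06 log units; within the scatter)). The step from hydrogen is the new information: methoxy and dimethylamino each gave a step beyond the scatter from compound 1, whereas hydroxymethyl does not, so not every group in this place separates from hydrogen. Hydroxymethyl is also the only one of these groups that counts a hydrogen-bond donor, but these numbers give no step beyond the scatter that can be tied to that donor, and no measurement is at hand that would explain them.

Still open, as far as these compounds go, is whether a carboxylic acid, a primary amine or a longer chain such as hydroxyethyl in this place would stand beyond the scatter of compound 1, or would stay as close to it as hydroxymethyl does. Also open, from the compounds shown here alone, is whether the same groups behave alike at other places on this six-membered aromatic ring, since all the substituted compounds here carry their group in one place only.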